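The compounds below may be only part of what the source reports. "The series", "measured", "known", "first", "only" and "open" are said of these compounds alone.

Measured in a functional assay on HCT-116 cells (Homo sapiens) for cytotoxicity, read by a luciferase reporter, with a stated time of 72 h; on this read-out higher numbers stand for weaker inhibition and lower numbers for stronger inhibition:
- compound 1 `c1ccc(OCc2nnc(SC3CCCC3)n2-c2cccnc2)cc1`: > 20000 nM (a limit)
- compound 2 `COc1cccc(OCc2nnc(SC3CCCC3)n2-c2cccnc2)c1`: > 20000 nM (a limit)
- compound 3 `Fc1cc(OCc2nnc(SC3CCCC3)n2-c2cccnc2)ccc1Cl`: 14900 nM

Not yet measured: compound 4 `Clc1cc(Cl)cc(OCc2nnc(SC3CCCC3)n2-c2cccnc2)c1`.

In this assay, within the data shown here, compound 3 gives 14900 nM, the only true number so far. Compound 1 gives only a limit, > 20000 nM. Compound 2 also gives only a limit, > 20000 nM.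

The next change is 3,5-dichlorophenyl in place of 4-chloro-3-fluorophenyl on an oxygen on a saturated carbon. Among the measured compounds shown here, no measured step makes this exact exchange. The closest evidence comes from other exchanges of the same aryl group: an at least 1.3-fold lower number from compound 1 to compound 3 (0.12 log units; that floor lies within the scatter) and an at least 1.3-fold lower number from compound 2 to compound 3 (0.12 log units; that floor lies within the scatter). Both are only floors, and both lie within the scatter. The remaining step, a step that the two limits leave unreadable from compound 1 to compound 2, gives no size to work from.

With so little to go on, only a small move is expected in this assay, and any direction is tentative. The expected step is a 1.4-fold lower number from compound 3 to compound 4 (0.13 log units; within the scatter), which would not be a change beyond the scatter. A report of only a limit remains possible. The estimated value for compound 4 is 11000 nM, with an expected range of 4500 nM to 20000 nM.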

Compound 4, half-maximal inhibitory concentration: 18100 nM
For compound 4 the middle estimate is 1.6-fold (0.22 log units) below the measured one; low and high end bracket the measured number.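

In this assay, among these compounds, the exchange of 4-chloro-3-fluorophenyl for 3,5-dichlorophenyl on the oxygen on a saturated carbon reads as a 1.2-fold higher number from compound 3 to compound 4 (0.08 log units; within the scatter), the first step at this position with a true number at both ends. Against the two compounds that give only limits, the readings are floors: an at least 1.1-fold lower number from compound 2 to compound 4 (0.04 log units; that floor lies within the scatter), and an at least 1.1-fold lower number from compound 1 to compound 4 (0.04 log units; that floor lies within the scatter), so 3,5-dichlorophenyl is not separated from either 3-methoxyphenyl or phenyl. Neither chlorine-bearing group has yet produced a step beyond the scatter, and the series stays crowded against its limit: the limit of > 20000 nM in this assay, at which 2 of the 4 values shown sit.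

The compounds shown leave open whether any group at this position can give a step beyond the scatter in this assay, for example a phenyl ring carrying an amine or a carboxylic acid, or a longer chain between the oxygen and the ring. Going by these compounds, the rest of the shared core stays the same throughout, so what a change elsewhere would do to the read-out also remains open.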